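Cytotoxicity notes on a diaminopyrrolopyrimidine nucleoside series

The source may hold more compounds than are shown below. What is called first, only, known or untested is meant among the compounds shown, and "the series" means these compounds.

Compound 1 `Nc1nc(N)c2c(-c3ccsc3)cn([C@@H]3O[C@H](CO)[C@@H](O)[C@H]3O)c2n1` gives > 100000 nM in an ADME assay on MRC5 cells (Homo sapiens), read by MTT assay, with a stated time of 72 h; on this read-out higher numbers stand for weaker inhibition and lower numbers for stronger inhibition.
Compound 2 `Cc1nc(N)c2c(-c3ccccc3)cn([C@@H]3O[C@H](CO)[C@@H](O)[C@H]3O)c2n1` gives > 100000 nM in this assay.

Both values shown are limits of the assay, not numbers. Compound 2 stands at the limit in this assay. Compound 1 stands at the same limit. Going by the values given here, no order can be drawn between the two, and no step between measured compounds that differ in one place is available; the only evidence on where the series stands is the limit of > 100000 nM in this assay, at which 2 of the 2 values shown sit.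

Compound 3 `Nc1nc(N)c2c(-c3ccccc3)cn([C@@H]3O[C@H](CO)[C@@H](O)[C@H]3O)c2n1` has not yet been measured in this assay. It differs from compound 2 by amino in place of methyl on an aromatic carbon. Compound 1 carries the same amino group in that place and sits at the limit (the limit of > 100000 nM in this assay, at which 2 of the 2 values shown sit), so the expected step of a number no higher from compound 2 to compound 3 (the limit leaves the size open) is none beyond the scatter. Compound 3 is estimated at 100000 nM, with a range from 50000 nM to 300000 nM, and is expected most likely to be reported again only as a limit.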

Compound 3, half-maximal inhibitory concentration: > 100000 nM
Compound 3 gave a limit, no number; the forecaster's own chance of this, stated with the estimate: 80%; the middle value sits exactly at the limit.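

In this assay compound 3 gives > 100000 nM, which is again a limit. The steps from compound 2 and from compound 1 to compound 3 therefore cannot be read. The compounds shown leave open whether amino or methyl, or phenyl or thiophen-3-yl, makes any difference in this read-out: the limit of > 100000 nM in this assay, at which 3 of the 3 values shown sit.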